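The source may report more compounds than this note shows. Statements on the series, on what has been measured and on what is new or still open speak of the compounds shown alone.

In a functional assay on C8166 cells (Homo sapiens) for cytotoxicity, read by MTT assay (on this read-out lower numbers stand for higher toxicity in this test and higher numbers for lower toxicity in this test), compound 1 `Cc1cc(S(N)(=O)=O)ccc1NC(=O)COc1ccc(Cl)cc1NC(=O)c1ccccc1C` gives 67300 nM and sits level with its two measured relatives, with compound 2 `Cc1cccc(C(=O)Nc2cc(Cl)ccc2OCC(=O)Nc2ccc(S(N)(=O)=O)cc2C)c1` giving 52900 nM and compound 3 `Cc1cc(S(N)(=O)=O)ccc1NC(=O)COc1ccc(Cl)cc1NC(=O)c1cccc(Cl)c1` giving 59700 nM here. All three numbers lie within the usual scatter of one another, so no order can be read among them.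

Compound 4 `Cc1cc(S(N)(=O)=O)ccc1NC(=O)COc1ccc(Cl)cc1NC(=O)c1cccc(F)c1` has not yet been measured. It keeps the core of compound 1 and carries 3-fluorophenyl in place of 2-methylphenyl on a carbonyl carbon with nothing else altered.

Two measured steps exchange the same group at that place. Putting in 3-methylphenyl gives a 1.3-fold lower number from compound 1 to compound 2 (0.10 log units; within the scatter) and putting in 3-chlorophenyl gives a 1.1-fold lower number from compound 1 to compound 3 (0.05 log units; within the scatter) and neither leaves the scatter. Chloro in place of methyl on an aromatic carbon gives a 1.1-fold higher number from compound 2 to compound 3 (0.05 log units; within the scatter) and also stays within it. Among the measured compounds shown here, no measured compound carries 3-fluorophenyl, so the expectation rests on these neighbours alone.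

The expected step in this assay is none beyond the scatter, with no firm direction, and the estimated change is a 1.1-fold lower number from compound 1 to compound 4 (0.05 log units; within the scatter) for this exchange. For compound 4 the estimate is 60000 nM with an expected range from 35000 nM to 100000 nM in this measurement.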

Compound 4, half-maximal cytotoxic concentration: 243000 nM
Compound 4: middle estimate off by 4.1-fold (0.61 log units), on the low side; the whole stated range lies below it.
By their numbers in this assay, from the lowest: compounds 2, 3 and 1 (each within the scatter of the next); then compound 4.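

In this assay this place on the carbonyl carbon had looked indifferent to the groups put there, yet 3-fluorophenyl in place of 2-methylphenyl gives a 3.6-fold higher number from compound 1 to compound 4 (0.56 log units; beyond the scatter), which means lower toxicity in this test. The exchange on the aromatic carbon tells the same story: fluoro in place of chloro gives a 4.1-fold higher number from compound 3 to compound 4 (0.61 log units; beyond the scatter), and fluoro in place of methyl gives a 4.6-fold higher number from compound 2 to compound 4 (0.66 log units; beyond the scatter), so a small exchange on the phenyl ring separates compound 4 from three compounds that stood level with one another. No supporting measurement accompanies these numbers to explain why fluoro stands apart from methyl and chloro here. 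

The compounds shown leave open whether this higher number belongs to fluoro alone or would also appear with a plain phenyl, or with a nitrile, a methoxy group or an amine on that ring. They also leave open whether the same exchange would shift the numbers in the same direction on a core carrying something other than the chloro group and the sulfonamide of compound 1.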